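Swapping cyclopropylamino for dimethylamino on the shared core

The source may hold more compounds than are shown below. What is called first, only, known or untested is meant among the compounds shown, and "the series" means these compounds.

Compound 1 `Nc1nc(NC2CC2)c2ncn(/C=C3/CC3(CO)CO)c2n1` sits at a limit in an ADME assay on Akata cells (Homo sapiens) for cytotoxicity, with a stated time of 7 days; a lower number here means that less compound is tolerated, a higher number that more compound is tolerated: compound 1 gives > 20000 nM, which is a limit of the assay rather than a number. Compound 2 `CCCNc1nc(N)nc2c1ncn2/C=C1/CC1(CO)CO` gives > 24000 nM, again a limit. Compound 3 `CC(C)CNc1nc(N)nc2c1ncn2/C=C1/CC1(CO)CO` gives > 24000 nM, also a limit. The two changes on the nitrogen on the aromatic ring, a step that the two limits leave unreadable from compound 1 to compound 2 and a step that the two limits leave unreadable from compound 1 to compound 3, and the further change a step that the two limits leave unreadable from compound 2 to compound 3, therefore say nothing about size: all three compounds are simply tolerated up to the point reached, as the limit of > 20000 nM in this assay, at which 1 of the 3 values shown sits, and the limit of > 24000 nM in this assay, at which 2 of the 3 values shown sit, show. The step to compound 4 `CN(C)c1nc(N)nc2c1ncn2/C=C1/CC1(CO)CO` replaces the group on that aromatic carbon: dimethylamino in place of cyclopropylamino on an aromatic carbon. For the measured compounds named here, none of the measured steps gives a readable number, so no direction beyond the scatter can be expected. The expected step is a step that the limit leaves unreadable from compound 1 to compound 4, meaning compound 4 is expected to stay at the limit as well. Compound 4 is thus estimated at about 30000 nM, between 15000 nM and 80000 nM.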

Compound 4, half-maximal cytotoxic concentration: > 24000 nM
Compound 4 gave a limit, no number (the forecaster's own chance of this, stated with the estimate: 85%); the middle value lies beyond the limit too.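

Compound 4 also gives only a limit, so its steps from compound 1, compound 2 and compound 3 in this assay cannot be read. The compounds shown leave open at what concentration any of the four harms the cells, and whether the amino group on the shared core matters.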